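This account rests on a few compounds, and the source may have more. Where it says the series, first, only, none or still open, it means among the compounds named here.

The measured compounds in this set:

compound 1, `CN(C)CCNC(=O)c1c(O)c2cccnc2n(-c2ccccc2)c1=O`, giving 22.6%
compound 2, `COc1ccccc1NC(=O)c1c(O)c2cccnc2n(-c2ccccc2)c1=O`, giving 8.1%
compound 3, `O=C(Nc1ccncc1)c1c(O)c2cccnc2n(-c2ccccc2)c1=O`, giving 34.9%

All three share one core and differ only in the group attached to an amide-type nitrogen. In a functional assay on the whole organism for inhibition, with Rattus norvegicus as the target, read by paw edema, at a dose of 100 mg/kg by the oral route (on this read-out higher numbers stand for more inhibition at the one dose given (going by the name of the read-out) and lower numbers for less inhibition), compound 3 stands highest of the three. Both steps toward it lie beyond the scatter: a number 12.3 percentage points higher from compound 1 to compound 3 (beyond the scatter) and a number 26.8 percentage points higher from compound 2 to compound 3 (beyond the scatter). On these numbers compound 3 gives the highest number of the three, with compound 1 nearest and compound 2 furthest away.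

Compound 4, `COc1ccc(NC(=O)c2c(O)c3cccnc3n(-c3ccccc3)c2=O)cn1`, differs from compound 3 in one place: 6-methoxypyridin-3-yl in place of pyridin-4-yl on an amide-type nitrogen. Going by the values given here, no measured step swaps one ring of this kind for another, so none bears directly on the change. The closest comparison is a number 26.8 percentage points higher from compound 2 to compound 3 (beyond the scatter), in which a ring carrying a methoxy group gave way to pyridin-4-yl and the number rose sharply; compound 4 brings a methoxy group back, though on a different ring. A modest downward step is therefore expected for compound 4, a number 9.9 percentage points lower from compound 3 to compound 4 (within the scatter), with considerable uncertainty. Compound 4 is estimated at 25%, expected to fall between 10% and 40%.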

Compound 4, a percentage reported as inhibition, in the whole organism at one dose (the size of the read-out at that dose, not a potency): 13.1%
Compound 4: the middle estimate sits 11.9 percentage points above what was measured; low and high end bracket the measured number.
By their numbers in this assay, from the lowest: compounds 2, 4 and 1 (each within the scatter of the next, the first and the last beyond it); then compound 3.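

In this assay, a number 21.8 percentage points lower from compound 3 to compound 4 (beyond the scatter) shows that keeping a six-membered aromatic ring with one hetero atom on the amide-type nitrogen is not enough to hold the number of compound 3, since 6-methoxypyridin-3-yl does not match pyridin-4-yl here. The two other comparisons, a number 5 percentage points higher from compound 2 to compound 4 (within the scatter) and a number 9.5 percentage points lower from compound 1 to compound 4 (within the scatter), place compound 4 within the scatter of both neighbours, although those two are themselves separated by a number 14.5 percentage points lower from compound 1 to compound 2 (beyond the scatter). Compound 2 and compound 4, which both carry a methoxy group, sit low in the set, but compound 1 goes against any simple methoxy rule, as it has no such group and still lies within the scatter of compound 4.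

The change from compound 3 to compound 4 alters both the ring attachment and the methoxy group at once, so a plain pyridin-3-yl group, or a pyridin-4-yl ring bearing a methoxy group, would be needed to tell those two parts apart. No measurement shown gives a reason for the drop.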